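The compounds below may be only part of what the source reports. "The series", "measured", "known", "first", "only" and "open" are said of these compounds alone.

Working notes on the series. In a functional assay on HUVEC cells (Homo sapiens) for antiproliferative activity, read by MTT assay, with a stated time of 48 h (a higher number here means a weaker inhibitor, a lower number a stronger inhibitor), compound 1 `Cc1cccc(NC(=O)Nc2nnc(Sc3ncnc4scc(-c5ccncc5)c34)s2)c1` gives 12200 nM, compound 2 `Cc1ccc(NC(=O)Nc2nnc(Sc3ncnc4scc(-c5ccncc5)c34)s2)cc1` gives 19300 nM and compound 3 `O=C(Nc1ccc(Cl)cc1)Nc1nnc(Sc2ncnc3scc(-c4ccncc4)c23)s1` gives 11600 nM. All three share one core and differ only in the aryl group on the amide-type nitrogen. The steps between them stay within the scatter: a 1.6-fold higher number from compound 1 to compound 2 (0.20 log units; within the scatter), a 1.1-fold lower number from compound 1 to compound 3 (0.02 log units; within the scatter) and a 1.7-fold lower number from compound 2 to compound 3 (0.22 log units; within the scatter). Compound 3 therefore sits alongside compound 1 and compound 2 with nothing separating it from either.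

Compound 4 `O=C(Nc1cccc(F)c1)Nc1nnc(Sc2ncnc3scc(-c4ccncc4)c23)s1` is not yet measured. Its difference from compound 3 is 3-fluorophenyl in place of 4-chlorophenyl on an amide-type nitrogen. The measured steps that bear on this all exchange one substituted phenyl for another on the same nitrogen, and each of them, the methyl-to-methyl shift, the methyl-to-chloro shift and the positional shift, stayed within the scatter. For the measured compounds named here, no measured step here moved the number beyond the scatter, so no step beyond the scatter is expected in this assay. The estimate for compound 4 is 14000 nM, with a range from 6000 nM to 35000 nM, which means an expected step of a 1.2-fold higher number from compound 3 to compound 4 (0.08 log units; within the scatter).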

Compound 4, half-maximal inhibitory concentration: 13700 nM
Estimate against measurement, compound 4: 1.0-fold (0.01 log units) above; low and high end bracket the measured number.
By their numbers in this assay, from the lowest: compounds 3, 1, 4 and 2 (each within the scatter of the next).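

In this assay, fluoro on an aromatic carbon in place of methyl leaves the number within the scatter (a 1.1-fold higher number from compound 1 to compound 4 (0.05 log units; within the scatter)), which extends the substituents on this phenyl from methyl and chloro to a third kind of atom. The 3-fluorophenyl group also changes both the halogen and its printed ring position relative to 4-chlorophenyl, yet this combined exchange on the amide-type nitrogen stays within the scatter (a 1.2-fold higher number from compound 3 to compound 4 (0.07 log units; within the scatter)). The same holds against 4-methylphenyl (a 1.4-fold lower number from compound 2 to compound 4 (0.15 log units; within the scatter)), so all four aryl groups remain indistinguishable here.

Still open, as far as these compounds go, is whether an amine or a carboxylic acid on this phenyl, or a longer alkyl chain in place of it, would move the number beyond the scatter. Nothing available explains why these exchanges leave the number so flat.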